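Second fluoro on the pendant phenyl: microsomal stability

The compounds below may be only part of what the source reports. "The series", "measured", "known", "first", "only" and "open" are said of these compounds alone.

Compound 3 `C[C@H](Nc1ncnc(N)c1C#N)c1cc(=O)n2cc(F)ccc2c1-c1cccc(F)c1` stands at the top of the three measured numbers in an ADME assay on microsomes from liver (Mus musculus), read by LC-MS, using NADPH, with a stated time of 30 min, tested at 1 uM; a higher number here means that more of the compound is left, a lower number that less of the compound is left: compound 3 gives 83%. Compound 2 `C[C@H](Nc1ncnc(N)c1C#N)c1cc(=O)n2cc(F)ccc2c1-c1ccccc1` gives 69%, and compound 1 `Cc1nc(N)nc(N[C@@H](C)c2cc3ccc(F)cn3c(=O)c2-c2ccccc2)c1C#N`, which carries a different core, gives 8%. The step from compound 2 to compound 3 is fluoro in place of hydrogen on an aromatic carbon and reads a number 14 percentage points higher from compound 2 to compound 3 (beyond the scatter), a modest rise that lies beyond the scatter.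

Compound 4 `C[C@H](Nc1ncnc(N)c1C#N)c1cc(=O)n2cc(F)ccc2c1-c1cc(F)cc(F)c1` has not yet been measured. It differs from compound 3 as follows: fluoro in place of hydrogen on an aromatic carbon. Among the compounds with values here, the only measured step that bears on this change is a number 14 percentage points higher from compound 2 to compound 3 (beyond the scatter), which is also fluoro in place of hydrogen on an aromatic carbon, and it went up. Compound 3 already gives a high number, so the room left for a further rise is small, and the read-out cannot exceed full recovery. A step in the same direction but smaller is expected, a number 5 percentage points higher from compound 3 to compound 4 (within the scatter), quite possibly within the scatter. Compound 4 is therefore estimated at 88%, with a range from 76% to 97%.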

Compound 4, percent of the compound remaining: 57%
Compound 4: the middle estimate sits 31 percentage points above what was measured; measured number below the stated range.
By their numbers in this assay, from the lowest: compound 1; then compound 4; then compound 2; then compound 3.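

In this assay the same replacement of hydrogen by fluoro on the pendant ring does not repeat its earlier result: a first fluoro gave a number 14 percentage points higher from compound 2 to compound 3 (beyond the scatter) and a second, meta to a fluoro group, gives a number 26 percentage points lower from compound 3 to compound 4 (beyond the scatter) in the opposite direction. The full change of 3,5-difluorophenyl in place of phenyl reads a number 12 percentage points lower from compound 2 to compound 4 (beyond the scatter) so the two fluoro groups together end below the plain phenyl, and among these compounds the outcome of a fluoro on this ring depends on what the ring already carries. No measurement at hand accounts for this reversal.

Whether the fall belongs to a second fluoro as such or to the 3,5-difluorophenyl arrangement in particular stays open, as this is the only ring shown with two substituents, and a chloro or methoxy group in the place of the second fluoro could help to separate the two readings. Also open is whether either fluoro step would apply to the core of compound 1 at 8% where only the plain phenyl is shown.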